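The compounds below may be only part of what the source reports. "The series", "measured", "known", "first", "only" and "open" are said of these compounds alone.

The shared core of these compounds ends in a chain that carries an aromatic ring, and the three measured members differ only in what sits on that ring. Compound 1 `CC1=C(/C=C/C(=O)/C=C/c2ccccc2)C(C)(C)CCC1` carries hydrogen there and, in a functional assay on IMR-32 cells (Homo sapiens) for cytotoxicity, read by sulforhodamine B assay, with a stated time of 48 h (a higher number here means a weaker inhibitor, a lower number a stronger inhibitor), compound 1 gives 20400 nM. Compound 2 `CC1=C(/C=C/C(=O)/C=C/c2ccc(Br)cc2)C(C)(C)CCC1` carries bromo and gives 10400 nM. Compound 3 `CC1=C(/C=C/C(=O)/C=C/c2ccc(F)cc2)C(C)(C)CCC1` carries fluoro and gives 7400 nM, the lowest of the three numbers; the step of a 2.8-fold lower number from compound 1 to compound 3 (0.44 log units; beyond the scatter) is modest, while a 1.4-fold lower number from compound 2 to compound 3 (0.15 log units; within the scatter) and a 2.0-fold lower number from compound 1 to compound 2 (0.29 log units; within the scatter) both stay within the scatter.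

Compound 4 `COc1ccc(/C=C/C(=O)/C=C/C2=C(C)CCCC2(C)C)cc1` is the next step: methoxy in place of fluoro on an aromatic carbon. Among the compounds with values here, no measured step swaps fluoro for methoxy, so the only guides are the steps above, which show that putting a group on this aromatic carbon moved the number little, at most modestly. The expected step of a 1.1-fold higher number from compound 3 to compound 4 (0.03 log units; within the scatter) is therefore none beyond the scatter. Compound 4 is estimated at 8000 nM, with a range from 3500 nM to 18000 nM.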

Compound 4, half-maximal inhibitory concentration: 23900 nM
Compound 4: middle estimate off by 3.0-fold (0.48 log units), on the low side, and the stated range ends below it.
By their numbers in this assay, from the lowest: compounds 3, 2, 1 and 4 (each within the scatter of the next, the first and the last beyond it).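

Methoxy is the first group on this aromatic carbon to lose the gain seen with fluoro: in this assay the number rises again (a 3.2-fold higher number from compound 3 to compound 4 (0.51 log units; beyond the scatter)) and also separates from that of the bromo compound (a 2.3-fold higher number from compound 2 to compound 4 (0.36 log units; beyond the scatter)), while it stays level with that of the unsubstituted compound (a 1.2-fold higher number from compound 1 to compound 4 (0.07 log units; within the scatter)). The position is therefore not indifferent to its group, and adding a group here does not by itself lower the number, since methoxy differs from fluoro and bromo but not from hydrogen. Nothing measured here explains why methoxy parts from fluoro and bromo.

From the compounds shown here alone, how an amine, a hydroxyl group or ethoxy on this same carbon would compare with methoxy and fluoro remains open. So does whether chloro would fall with fluoro and bromo.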